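Swapping a Methyl for Trifluoromethoxy on the Benzyl Ring

A few compounds are considered here, and "the series" means these few. Any claim that something is new, unique, unknown or untested is made for them only; others in the source may bear on it.

Two measured compounds set the scene. Compound 1 `Cc1ccc(CN2CCC(NC(=O)C(C)(C)Oc3ccc(C(=O)c4ccc(Cl)cc4)cc3)CC2)cc1` is tested in a functional assay on RAW264.7 cells (Mus musculus) for inhibition, read by polymerase chain reaction, with stated times of 12 h and 6 h (on this read-out lower numbers stand for stronger inhibition and higher numbers for weaker inhibition), and gives 8560 nM. Compound 2 `O=C(COc1ccc(C(=O)c2ccccc2)cc1)NC1CCN(Cc2ccccc2)CC1`, which shares the core but lacks the chlorine and the two methyl groups next to the amide, gives 15000 nM in this assay. The two numbers lie within the usual scatter of each other, so the data do not separate compound 1 from compound 2, and compound 1 simply stands at one end of a pair that is indistinguishable on this read-out.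

Compound 3 `CC(C)(Oc1ccc(C(=O)c2ccc(Cl)cc2)cc1)C(=O)NC1CCN(Cc2ccc(OC(F)(F)F)cc2)CC1` differs from compound 1 in one place: trifluoromethoxy in place of methyl on an aromatic carbon. For the measured compounds named here, no measured pair shows this change, so there is no reference step. The change is expected to shift the number little, in either direction, within the scatter. On that basis compound 3 is expected to give about 7000 nM, with a range from 2500 nM to 20000 nM, corresponding to an estimated step of a 1.2-fold lower number from compound 1 to compound 3 (0.09 log units; within the scatter).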

Compound 3, half-maximal inhibitory concentration: 9760 nM
For compound 3 the middle estimate is 1.4-fold (0.14 log units) below the measured one; the range from low to high includes it.
By their numbers in this assay, from the lowest: compounds 1, 3 and 2 (each within the scatter of the next).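

For the compounds shown here, the step is a 1.1-fold higher number from compound 1 to compound 3 (0.06 log units; within the scatter) in this assay, the first direct look at a change on this benzyl ring. At this aromatic carbon, para to a large group, trifluoromethoxy with its 5 heavy atoms and 1 hydrogen-bond acceptor stands in place of methyl with its 1 heavy atom, and the data do not separate the two compounds. No separate measurement on these compounds bears on this result.

On these data alone, whether an amine or a carboxylic acid on the same aromatic carbon would also stay within the scatter of compound 1 remains open. The compounds shown also leave open whether any change to the shared core can give a number clearly apart from these three, each of which lies within the scatter of the next.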